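The source may hold more compounds than are shown below. What is called first, only, known or untested is meant among the compounds shown, and "the series" means these compounds.

Measured so far:
compound 1 `COc1ccc(-n2nc(C(N)=O)nc2-c2cc(OC)c(OC)c(OC)c2)cc1` — 106%
compound 2 `COc1ccc(-n2nc(C(=O)Nc3cccc(F)c3)nc2-c2cc(OC)c(OC)c(OC)c2)cc1` — 106%

In a functional assay on the whole organism for inhibition, with Rattus norvegicus as the target, read by paw edema, with stated times of 30 min and 3 h, at a dose of 0.28 mmol/kg by the oral route (a higher number here means more inhibition at the dose given (going by the name of the read-out), a lower number less inhibition), compound 1 gives 106%. Compound 2 carries a 3-fluorophenyl in place of hydrogen on an amide-type nitrogen, and in this assay compound 2 gives 106%. That single step, no change at the digits printed from compound 1 to compound 2 (within the scatter), lies within the scatter, so compound 2 stands level with compound 1 at the digits shown, and its nearest neighbour among the measured compounds is compound 1.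

Compound 3, `COc1ccc(-n2nc(C(=O)Nc3ccc(C(F)(F)F)cc3)nc2-c2cc(OC)c(OC)c(OC)c2)cc1`, has not yet been measured in this assay. It differs from compound 2 in one place: 4-(trifluoromethyl)phenyl in place of 3-fluorophenyl on an amide-type nitrogen. Going by the values given here, the only measured step that bears on this change is the one in which a 3-fluorophenyl entered on an amide-type nitrogen; that step, no change at the digits printed from compound 1 to compound 2 (within the scatter), did not move the number beyond the scatter. Nothing measured here speaks to a 4-(trifluoromethyl)phenyl in that place, so the expectation rests on that single step alone. On that basis compound 3 is expected to give about 100% in this assay, within a range of 75% to 115%. The expected step, a number 6 percentage points lower from compound 2 to compound 3 (within the scatter), is estimated to lie within the scatter.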

Compound 3, a percentage reported as inhibition, in the whole organism at one dose (the size of the read-out at that dose, not a potency): 96%
For compound 3 the middle estimate is 4 percentage points above the measured one, and the stated range covers the measured number.
By their numbers in this assay, from the lowest: compounds 3, 1 and 2 (each within the scatter of the next).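

In this assay the exchange of 3-fluorophenyl for 4-(trifluoromethyl)phenyl on the amide-type nitrogen gives a number 10 percentage points lower from compound 2 to compound 3 (within the scatter) and so shows that this nitrogen carries a second, differently substituted phenyl group without a step beyond the scatter. Set against the amide hydrogen itself, the new group gives a number 10 percentage points lower from compound 1 to compound 3 (within the scatter) and thus extends to a second group what the earlier pair showed for 3-fluorophenyl alone. Nothing available here accounts for why the read-out holds across these groups.

The compounds shown leave open whether the same place accepts something other than a phenyl group, such as a benzyl group or a short alkyl chain, and whether a carboxylic acid or an amine on the phenyl ring would keep the number at this level. With all three compounds read at one dose, they also leave open whether lower doses would separate them.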